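From allyl to (1H-benzimidazol-2-yl)methyl on sulfur

The compounds below may be only part of what the source reports. "The series", "measured", "known", "first", "only" and "open" are said of these compounds alone.

Measured in a functional assay on PC-9 cells (Homo sapiens) for inhibition, read by MTT assay, with a stated time of 72 h; a higher number here means a weaker inhibitor, a lower number a stronger inhibitor:
- Compound 1 `Cc1cc(Nc2cc(-c3ccccc3)[nH]n2)n2nc(SCc3c(Cl)cccc3Cl)nc2n1`: 5180 nM
- Compound 2 `C=CCSc1nc2nc(C)cc(Nc3cc(-c4ccccc4)[nH]n3)n2n1`: > 50000 nM

Compound 2 reads > 50000 nM, which is a limit of this assay and not a number.

Compound 3 `Cc1cc(Nc2cc(-c3ccccc3)[nH]n2)n2nc(SCc3nc4ccccc4[nH]3)nc2n1` carries 1H-benzimidazol-2-yl in place of vinyl on a saturated chain carbon bound to a sulfur. For the measured compounds named here, one measured step bears on this change: an at least 9.6-fold higher number from compound 1 to compound 2 (0.98 log units; beyond the scatter), beyond the scatter, with 2,6-dichlorophenyl giving way to vinyl at the same place. Compound 3 reverses the vinyl part of that step and again places an aromatic group there, so a move back toward compound 1 at 5180 nM is expected, though this rests on a single pair. The expected change is an at least 5.5-fold lower number from compound 2 to compound 3 (0.74 log units; beyond the scatter), toward a lower number and of similar size to the measured step. For compound 3 the estimated value is 9000 nM, with an expected range of 2500 nM to 40000 nM.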

Compound 3, half-maximal inhibitory concentration: 4840 nM
Compound 3: the middle estimate sits 1.9-fold (0.27 log units) above what was measured; the measured number falls inside the stated range.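

In this assay, 1H-benzimidazol-2-yl in place of vinyl on the saturated chain carbon bound to a sulfur gives an at least 10-fold lower number from compound 2 to compound 3 (1.01 log units; beyond the scatter). As far as these compounds go, compound 2 stands at > 50000 nM, which is a limit of the assay and not a number, so the full size of that step stays unknown. The new point is that two different aromatic groups read alike at this place: 2,6-dichlorophenyl and 1H-benzimidazol-2-yl, the latter with a hydrogen-bond donor and acceptor, show a 1.1-fold lower number from compound 1 to compound 3 (0.03 log units; within the scatter).

Still open, from the compounds shown here alone, is whether any aromatic group at this place would restore the activity, or whether something specific to these two groups is required. Plain phenyl, an amine or a carboxylic acid at the same place would test this, and none of the compounds shown yet says whether this place can give a stronger inhibitor.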